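The compounds below may be only part of what the source reports. "The series", "measured", "known", "first", "only" and "open" are said of these compounds alone.

Series notes. Compound 1 `CC(C)(C)OC(=O)N1CCC(O[C@H]2CC[C@H](Oc3ccc(S(C)(=O)=O)cc3F)CC2)CC1` gives 61 nM in a functional assay on isolated protein for agonist activity at Glucose-dependent insulinotropic receptor (Rattus norvegicus), read by HTRF and cAMP accumulation; on this read-out lower numbers stand for an effect already at smaller amounts and higher numbers for an effect only at larger amounts of compound. Among the compounds with values here, compound 2 `C[C@H](CF)OC(=O)N1CCC(O[C@H]2CC[C@H](Oc3cnc(S(C)(=O)=O)cn3)CC2)CC1` gives 317 nM in this assay, the higher of the two numbers known so far; the gap to compound 1 is beyond the scatter. Compound 3 `CS(=O)(=O)c1cnc(O[C@H]2CC[C@H](OC3CCN(C(=O)C4(C(F)(F)F)CCCC4)CC3)CC2)cn1` is not yet measured. It differs from compound 2 in one place: a group of 9 heavy atoms (6 carbon, 3 fluorine; one five-membered non-aromatic ring of carbon only) in place of a group of 5 heavy atoms (3 carbon, 1 oxygen, 1 fluorine; no ring), on a carbonyl carbon. No measured pair in the series isolates this change, so the direction rests on no shown step. The step from compound 2 to compound 3 is expected to be modest, toward a smaller number, a 1.8-fold lower number from compound 2 to compound 3 (0.25 log units; within the scatter), but not clearly beyond the scatter. Compound 3 is estimated at 180 nM in this assay, within a range of 50 nM to 650 nM.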

Compound 3, half-maximal effective concentration: 108 nM
Beside the measured number, compound 3's estimate is 1.7-fold (0.22 log units) above it; the range from low to high includes it.
By their numbers in this assay, from the lowest: compounds 1 and 3 (each within the scatter of the next); then compound 2.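

In this assay the group of 9 heavy atoms, with its one five-membered non-aromatic ring of carbon only, gives a 2.9-fold lower number from compound 2 to compound 3 (0.47 log units; beyond the scatter) on a carbonyl carbon whose other neighbour is an amide-type nitrogen in a ring. This position therefore accepts a larger, ring-bearing group with 0 hydrogen-bond acceptors, so the acceptor of the group that leaves is not needed for activity here. No evidence accounts for the step. The compounds shown do not separate the contribution of the ring from that of the fluorines, and how an amine or a longer carbon chain would read at this position stays open.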